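Cytotoxicity on Vero Cells: From Fluorobenzyl to Phenyl

The compounds below may be only part of what the source reports. "The series", "measured", "known", "first", "only" and "open" are said of these compounds alone.

Measured so far in an ADME assay on Vero cells (Chlorocebus sabaeus) for cytotoxicity, read by MTT assay, with a stated time of 48 h; on this read-out higher numbers stand for weaker inhibition and lower numbers for stronger inhibition:
- compound 1 `O=c1nc(N2CCN(CC3CCCCC3)CC2)sc2c([N+](=O)[O-])cc(C(F)(F)F)cc12` gives > 64 ug/mL, a limit of the assay.
- compound 2 `O=c1nc(NCc2cccc(F)c2)oc2c([N+](=O)[O-])cc(C(F)(F)F)cc12` gives > 64 ug/mL, a limit of the assay.
- compound 3 `O=C1CN(c2nc(=O)c3cc(C(F)(F)F)cc([N+](=O)[O-])c3o2)CCN1CC1CCCCC1` gives 25.4 ug/mL.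

Compound 2 therefore stands at the top of what this assay can report: its value is a limit, not a number, and it shares that position with compound 1, as noted by the limit of > 64 ug/mL in this assay, at which 2 of the 3 values shown sit. Only compound 3 returns an actual number in this assay. The next compound, compound 4 `O=c1nc(Nc2ccccc2)oc2c([N+](=O)[O-])cc(C(F)(F)F)cc12`, differs from compound 2 in one place: phenyl in place of 3-fluorobenzyl on a nitrogen on an aromatic ring. Because the starting point of compound 2 is already a limit in this assay, > 64 ug/mL, no step beyond the scatter can be read off, and a small change of this kind is expected to give a step that the limit leaves unreadable from compound 2 to compound 4, that is, no shift beyond the scatter. Compound 4 is thus expected to come out at 70 ug/mL, with a likely range from 30 ug/mL to 150 ug/mL, and most probably again only a limit.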

Compound 4, half-maximal inhibitory concentration: 37.9 ug/mL
Compound 4: the middle estimate sits 1.8-fold (0.27 log units) above what was measured; measured number inside the range.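

In this assay, compound 4 returns an actual number, so a compound with an anilino group at this position can be read inside the range of the assay. The change from 3-fluorobenzyl to phenyl on this nitrogen gives an at least 1.6-fold lower number from compound 2 to compound 4 (0.22 log units; that floor lies within the scatter); that figure is only a floor, so the true step may be larger, but it is not shown to exceed the scatter. Compound 2 remains a limit of the assay and not a number: the limit of > 64 ug/mL in this assay, at which 2 of the 4 values shown sit.

The change removes the fluorine and the benzyl carbon together, so the compounds shown leave open which of the two matters; a plain benzyl or a 3-fluorophenyl group on the same nitrogen would separate them. From the compounds shown here alone, how a pyridyl or cyclohexyl group would read at this position also remains open.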